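Ester in Place of Amide on a Long Chain

The source may report more compounds than this note shows. Statements on the series, on what has been measured and on what is new or still open speak of the compounds shown alone.

Measured compounds:
Compound 1, `CC(C)(C)C(=O)OCC1(CO)C/C(=C\CCCCCCCCCCCO)C(=O)O1`, gives 5.81 ug/mL in a functional assay on SK-MEL-5 cells (Homo sapiens) for antiproliferative activity; a higher number here means a weaker inhibitor of growth, a lower number a stronger inhibitor of growth.
Compound 2, `CC(=O)OCCCCCCCCCCCCCCC/C=C1\CC(CO)(COC(=O)C(C)(C)C)OC1=O`, gives 5.62 ug/mL in this assay.
Compound 3, `CC(=O)NCCCCCCCCCCCCCCC/C=C1\CC(CO)(COC(=O)C(C)(C)C)OC1=O`, gives only a limit in this assay, namely > 10 ug/mL.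

Compound 3 therefore stands at the limit of > 10 ug/mL in this assay, at which 1 of the 3 values shown sits, so no exact number is known for it. Compound 4, `CC(C)(C)C(=O)OCCCCCCCCCCCCCCC/C=C1\CC(CO)(COC(=O)C(C)(C)C)OC1=O`, differs from compound 3 by ((tert-butyl)carbonyl)oxy in place of acetamido on a saturated chain carbon, ten or more bonds along the chain from a double-bonded chain carbon. The measured step that bears on this change is an at least 1.7-fold higher number from compound 2 to compound 3 (0.25 log units; that floor lies within the scatter); run backwards, it suggests that returning to an ester lowers the number, and the entering group resembles acetoxy. The step of an at least 1.7-fold higher number from compound 1 to compound 3 (0.23 log units; that floor lies within the scatter) points the same way. A drop below the limit is thus expected, an at least 1.7-fold lower number from compound 3 to compound 4 (0.25 log units; that floor lies within the scatter). Compound 4 is estimated to give 5.6 ug/mL, expected between 3 ug/mL and 11 ug/mL.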

Compound 4, concentration for 50% growth inhibition: 3.46 ug/mL
Beside the measured number, compound 4's estimate is 1.6-fold (0.21 log units) above it, within the range that was stated.
By their numbers in this assay, from the lowest: compounds 4, 2 and 1 (each within the scatter of the next). At a limit, above all of these: compound 3.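

Placing ((tert-butyl)carbonyl)oxy instead of acetamido on this saturated chain carbon gives the first step here that clears the usual scatter (an at least 2.8-fold lower number from compound 3 to compound 4 (0.46 log units; beyond the scatter)). Among the compounds without the amide, the end of the chain makes no clear difference, with tert-butyl in place of methyl on the carbonyl carbon (a 1.6-fold lower number from compound 2 to compound 4 (0.21 log units; within the scatter)) and with the longer ester in place of hydroxy (a 1.7-fold lower number from compound 1 to compound 4 (0.23 log units; within the scatter)). Compound 3 itself stands only at a limit: the limit of > 10 ug/mL in this assay, at which 1 of the 4 values shown sits.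

In this assay, going by these compounds, it remains open how a free amine, a carboxylic acid or a shorter chain would behave at this place.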